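Caffeic Amides: From Piperazin-1-yl to Piperidin-1-yl

The compounds below may be only part of what the source reports. "The series", "measured", "known", "first", "only" and "open" are said of these compounds alone.

Compound 1 `O=C(/C=C/c1ccc(O)c(O)c1)NC1CCCC1`: 30000 nM
Compound 2 `O=C(/C=C/c1ccc(O)c(O)c1)N1CCNCC1`: > 40000 nM

In a functional assay on B16 cells (Mus musculus) for inhibition (on this read-out lower numbers stand for stronger inhibition and higher numbers for weaker inhibition), compound 1 gives 30000 nM. Compound 2 gives > 40000 nM, and this is a limit of the assay, not a number.

Compound 3 `O=C(/C=C/c1ccc(O)c(O)c1)N1CCCCC1` differs from compound 2 in one place, on a carbonyl carbon, where piperidin-1-yl takes the place of piperazin-1-yl: piperidin-1-yl in place of piperazin-1-yl on a carbonyl carbon.

Going by the values given here, only one measured step bears on this change: an at least 1.3-fold higher number from compound 1 to compound 2 (0.12 log units; that floor lies within the scatter). It replaced cyclopentylamino with piperazin-1-yl on a carbonyl carbon, and its floor lies within the scatter, so it gives no firm size for the new step. Among the compounds with values here, the only true number in this small series is that of compound 1 at 30000 nM, so compound 3 is expected to fall in the same region, with weak inhibition. In this assay the expected step is an at least 1.4-fold lower number from compound 2 to compound 3 (0.15 log units; that floor lies within the scatter), pointing modestly towards stronger inhibition. A result at the limit would not be a surprise. For compound 3 the estimated value is 28000 nM, with an expected range from 10000 nM to 60000 nM.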

Compound 3, half-maximal inhibitory concentration: 24000 nM
The estimate for compound 3 lay 1.2-fold (0.07 log units) above the measured number; the range from low to high includes it.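

In this assay, the swap of piperazin-1-yl for piperidin-1-yl on the carbonyl carbon gives an at least 1.6-fold lower number from compound 2 to compound 3 (0.22 log units; that floor lies within the scatter), so this change brings no shift that can be told from ordinary repeat variation, even though it removes the hydrogen-bond donor and acceptor counted on piperazin-1-yl. That figure is only a floor, since the value for compound 2 is a limit and not a number: the limit of > 40000 nM in this assay, at which 1 of the 3 values shown sits. Going by these compounds alone, compound 3 does give a true number, which allows the first comparison of two real values at this position, and the result is a 1.3-fold lower number from compound 1 to compound 3 (0.10 log units; within the scatter), so cyclopentylamino and piperidin-1-yl cannot be told apart here.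

From the compounds shown here alone, how much weaker compound 2 really is remains unknown, so the full size of the step from piperazin-1-yl to piperidin-1-yl stays open. Going by these compounds, it is also open whether any group on this carbonyl carbon, such as morpholin-4-yl, an open-chain diethylamino group or a longer chain ending in a carboxylic acid, would move the number beyond the scatter, given that all the values shown here sit in the same weak region.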